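This account rests on a few compounds, and the source may have more. Where it says the series, first, only, none or still open, it means among the compounds named here.

Measured so far in a functional assay for agonist activity at Alpha-1A adrenergic receptor (Homo sapiens); on this read-out higher numbers stand for larger maximal responses and lower numbers for smaller maximal responses:
Compound 1 `CS(=O)(=O)c1cc(F)ccc1NCC1=NCCN1` gives 61%.
Compound 2 `CS(=O)(=O)c1ccc(Cl)cc1NCC1=NCCN1` gives 91%.
Compound 3 `CSc1cc(F)ccc1NCC1=NCCN1` gives 93%.

Compound 2 stands second highest of the three; its gap to compound 3 is within the scatter, its gap to compound 1 beyond it. Among the measured compounds shown here, the one measured step, a number 32 percentage points higher from compound 1 to compound 3 (beyond the scatter), concerns a different group at a different place and does not bear on the next change. Compound 4 `COc1ccc(S(C)(=O)=O)c(NCC2=NCCN2)c1` is not yet measured; it differs from compound 2 by methoxy in place of chloro on an aromatic carbon. For the measured compounds named here, no measured pair shows this exchange, so there is no basis to expect a shift beyond the scatter; the step from compound 2 is expected as a number 6 percentage points lower from compound 2 to compound 4 (within the scatter). Compound 4 is therefore estimated at 85%, with a range from 65% to 100% in this assay.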

Compound 4, largest response reached (reported as maximum), in percent of the reference or control that the assay uses: 102%
Estimate against measurement, compound 4: 17 percentage points below; measured number outside the range, above it.
By their numbers in this assay, from the lowest: compound 1; then compounds 2, 3 and 4 (each within the scatter of the next, the first and the last beyond it).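

At the carbon para to a methylsulfonyl group, methoxy in place of chloro gives a number 11 percentage points higher from compound 2 to compound 4 (beyond the scatter) in this assay. This carbon therefore accepts more than a halogen: methoxy, with its 2 heavy atoms and 1 hydrogen-bond acceptor, raises the maximal response rather than lowering it. No available evidence accounts for this rise.

Going by these compounds, whether the rise is specific to methoxy remains open; ethoxy, a hydroxyl or dimethylamino at this carbon would test it. Also open, on these data alone, is whether the same exchange holds with methylsulfanyl in place of methylsulfonyl, since compound 3 carries fluoro at a different place.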